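The source may report more compounds than this note shows. Statements on the series, on what has been measured and on what is new or still open speak of the compounds shown alone.

Compound 1 `CNC(=O)c1cccc(C#Cc2ccccc2Nc2ncnc3ccc(Cl)nc23)c1` stands at the boundary of an assay on isolated protein for inhibition of MAP kinase-interacting serine/threonine-protein kinase 1 (Homo sapiens), read by HTRF, in the presence of a further agent that is not named here; on this read-out higher numbers stand for weaker inhibition and lower numbers for stronger inhibition. In this assay compound 1 gives > 10000 nM, a limit of the assay rather than a measured number (the limit of > 10000 nM in this assay, at which 1 of the 2 values shown sits). Compound 2 `N#Cc1ccc(Nc2ncnc3ccc(-c4ccc(C(=O)N5CCNCC5)cc4)nc23)cc1` is another compound on the shared core, and in this assay compound 2 gives 0.15 nM. Compound 3 `O=C(c1cccc(C#Cc2ccccc2Nc2ncnc3ccc(Cl)nc23)c1)N1CCNCC1` differs from compound 1 by piperazin-1-yl in place of methylamino on a carbonyl carbon. For the measured compounds named here, no measured step covers such a change here, so the expectation rests on compound 1 sitting at the limit, and a step no larger than the scatter is expected, a number no higher from compound 1 to compound 3 (the limit leaves the size open). Compound 3 is thus expected to give 10000 nM, within 1000 nM to 50000 nM.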

Compound 3, half-maximal inhibitory concentration: > 10000 nM
Compound 3: a limit, no number; the forecaster's own chance of this, stated with the estimate: 70%; the middle value sits exactly at the limit.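

Compound 1 and compound 3 both give a limit rather than a number, so no step can be read between them: the limit of > 10000 nM in this assay, at which 2 of the 3 values shown sit. As far as these compounds go, whether piperazin-1-yl in place of methylamino on a carbonyl carbon alters inhibition on this core remains open.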